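This account rests on a few compounds, and the source may have more. Where it says the series, first, only, none or still open, it means among the compounds named here.

In an ADME assay (liver) for metabolic stability, with Liver microsome (Rattus norvegicus) as the target, read by LC-MS, using microsomes, with a stated time of 30 min, tested at 4 uM (on this read-out higher numbers stand for a more stable compound and lower numbers for a less stable compound), compound 2 `Cc1nc(N2CCN(C)CC2)c2nc(-c3ccccc3C#N)n(C3CCOCC3)c2n1` stands lower of the two measured compounds at 21% and compound 1 `Cc1nc(N2CCN(C)CC2)c2nc(-c3ccccc3C(F)(F)F)n(C3CCOCC3)c2n1` gives 38% in the same read-out. Compound 3 `Cc1nc(N2CCN(C)CC2)c2nc(-c3ccccc3F)n(C3CCOCC3)c2n1` carries fluoro in place of cyano on an aromatic carbon ortho to a large group (fluoro in place of cyano on an aromatic carbon). For the measured compounds named here, the only measured step at this place is modest (a number 17 percentage points lower from compound 1 to compound 2 (beyond the scatter)) and replaces trifluoromethyl with cyano. Going by the values given here, no fluoro compound has been measured, so a smaller upward move is expected, with the estimated step being a number 9 percentage points higher from compound 2 to compound 3 (within the scatter) and possibly not clearing the scatter. The estimate for compound 3 is 30% with an expected range from 16% to 47% in this assay.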

Compound 3, percent of the compound remaining: 30%
Estimate against measurement, compound 3: no gap at the digits printed; measured number inside the range.
By their numbers in this assay, from the lowest: compounds 2, 3 and 1 (each within the scatter of the next, the first and the last beyond it).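

In this assay, fluoro on this aromatic carbon gives a number 9 percentage points higher from compound 2 to compound 3 (within the scatter) and a number 8 percentage points lower from compound 1 to compound 3 (within the scatter), so compound 3 cannot be separated from either earlier compound, although those two differ beyond the scatter. At this place, the read-out therefore resolves the nitrile and trifluoromethyl pair but does not place fluoro apart from either group. Nothing available accounts for these readings.

On these data alone, whether a methoxy group or an amine on this aromatic carbon would separate from compound 3 remains open. Also open, as far as these compounds go, is whether the fluoro reading would hold with a different group in place of the methylpiperazine.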